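The compounds below may be only part of what the source reports. "The series", "measured", "known", "first", "only" and "open" are said of these compounds alone.

Measured compounds:
compound 1, `CC(=O)N1CCc2cc(-c3cccc4c3CCCC4)cc(N3CCCC3=O)c21` — 3.5
compound 2, `CC(=O)N1CCc2cc(-c3cccc4c3CCCC4)cc(N3CCCCC3=O)c21` — 3.8
compound 3, `O=C([C@@H]1C[C@H]1c1cccc(N2CCCC2=O)c1)N1CCN(C2CCC2)CC1` — 2

In a physicochemical assay for lipophilicity, at pH 7.4 (on this read-out lower numbers stand for lower lipophilicity and higher numbers for higher lipophilicity), compound 3 sits lowest of the three, with compound 1 the nearest and compound 2 the furthest, both gaps beyond the scatter. The difference between the core of compound 1 and the core of compound 3 is not broken down here.

Compound 4, `O=C([C@@H]1C[C@H]1c1cccc(N2CCCCC2=O)c1)N1CCN(C2CCC2)CC1`, has not yet been measured in this assay. It differs from compound 3 as follows: 2-oxopiperidin-1-yl in place of 2-oxopyrrolidin-1-yl on an aromatic carbon. The same kind of change has already been made once, from compound 1 to compound 2: 2-oxopiperidin-1-yl in place of 2-oxopyrrolidin-1-yl on an aromatic carbon. The two places are not the same word for word: in compound 1 the aromatic carbon is part of a fused or bridged system of two rings, ortho to a fused ring and meta to a fused ring, while in compound 3 it is only meta to a large group. Among the measured compounds shown here, the earlier step, a number 0.30 log units higher from compound 1 to compound 2 (within the scatter), is the single precedent.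

For compound 4 the expected step is a number 0.30 log units higher from compound 3 to compound 4 (within the scatter), resting on that one precedent, so compound 4 is estimated at 2.3, between 1.9 and 2.7.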

Compound 4, distribution coefficient: 1.6
Estimate against measurement, compound 4: 0.70 log units above; the whole stated range lies above it.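

In this assay, among the compounds shown here, putting 2-oxopiperidin-1-yl in place of 2-oxopyrrolidin-1-yl gives a number 0.40 log units lower from compound 3 to compound 4 (beyond the scatter) on an aromatic carbon meta to a large group, whereas the same change on the core of compound 1 gave a number 0.30 log units higher from compound 1 to compound 2 (within the scatter) and so no step that can be told from the scatter. This shows that the change does not carry from the core of compound 1 to the core of compound 3 as a fixed increment, although it does not establish a general rule for either core, since each rests on a single pair. No available evidence bears on why the two steps differ.

The compounds shown leave open how a larger lactam such as 2-oxoazepan-1-yl, or an open-chain acetamido group, would read at the same place on either core. They also leave open whether the step from compound 3 to compound 4 would persist with a carboxylic acid in place of the cyclobutyl group.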